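Lengthening the chain on the shared core

This account rests on a few compounds, and the source may have more. Where it says the series, first, only, none or still open, it means among the compounds named here.

Measured so far:
compound 1, `Nc1ccn(CCCCc2ccccc2)c(=O)n1`, 1000000 nM in an assay on isolated protein for inhibition of deoxycytidine kinase (Rattus norvegicus); a higher number here means a weaker inhibitor, a lower number a stronger inhibitor
compound 2, `CCCn1ccc(N)nc1=O`, 12000000 nM in this assay

Compound 2 stands highest of the two numbers, and compound 1 sits below it by a gap beyond the usual scatter. The unmeasured compound 3, `CC(C)CCn1ccc(N)nc1=O`, differs from compound 2 by one change: isopropyl in place of methyl on a saturated chain carbon, two bonds along the chain from an aromatic nitrogen. Since compound 1, with its longer chain, gives 1000000 nM, a modest step toward a lower number is expected in this assay, not larger than that gap. Compound 3 is therefore estimated at 4000000 nM (range 1500000 nM to 12000000 nM), an expected step of a 3.0-fold lower number from compound 2 to compound 3 (0.48 log units; beyond the scatter).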

Compound 3, half-maximal inhibitory concentration: 5000000 nM
The estimate for compound 3 lay 1.3-fold (0.10 log units) below the measured number, within the range that was stated.
By their numbers in this assay, from the lowest: compound 1; then compound 3; then compound 2.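

In this assay, among the compounds shown here, isopropyl in place of methyl on a saturated chain carbon, two bonds along the chain from an aromatic nitrogen, gives a 2.4-fold lower number from compound 2 to compound 3 (0.38 log units; beyond the scatter) and so provides the first step that can be read at a single place. This position therefore responds to the change, though only modestly. Nothing measured here accounts for the step.

On these data alone, whether the branching matters remains open, as an unbranched chain of similar length could be compared with the isopropyl end. It is also unknown how a phenyl, hydroxyl or amine at this carbon would compare.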